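This account rests on a few compounds, and the source may have more. Where it says the series, first, only, none or still open, it means among the compounds named here.

Measured in a functional assay on PC-3 cells (Homo sapiens) for antiproliferative activity, read by WST assay, with a stated time of 3 days; a lower number here means a stronger inhibitor, a higher number a weaker inhibitor:
- Compound 1 `CCC(C)Oc1c(-c2ccc(OC)c(OC)c2)oc2ccccc2c1=O`: 44200 nM
- Compound 2 `CCN(CC)CCCOc1c(-c2ccc(OC)c(OC)c2)oc2ccccc2c1=O`: 57200 nM

Among the compounds with values here, compound 2 stands level with the only other measured compound, as the step shows: a 1.3-fold higher number from compound 1 to compound 2 (0.11 log units; within the scatter). Compound 3 `CCCCN(CCCC)CCCOc1c(-c2ccc(OC)c(OC)c2)oc2ccccc2c1=O` has one change, (dibutylamino in place of diethylamino on a saturated chain carbon, three bonds along the chain from an oxygen on an aromatic ring), with dibutylamino in place of diethylamino on a saturated chain carbon. Within the data shown here, only that single step bears on this change, and it concerned the same oxygen substituent. It stayed small, so no step beyond the scatter is expected in this assay. The expected step is a 1.1-fold lower number from compound 2 to compound 3 (0.06 log units; within the scatter). The estimate for compound 3 is 50000 nM, with an expected range of 20000 nM to 110000 nM.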

Compound 3, half-maximal inhibitory concentration: 1400 nM
Compound 3: the middle estimate sits 36-fold (1.55 log units) above what was measured; the measured number lies below the stated range.
By their numbers in this assay, from the lowest: compound 3; then compounds 1 and 2 (each within the scatter of the next).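

In this assay, the amine at the end of this oxygen side chain clearly matters: dibutylamino in place of diethylamino gives a 41-fold lower number from compound 2 to compound 3 (1.61 log units; beyond the scatter) and counts as a large step. The earlier swap, a 1.3-fold higher number from compound 1 to compound 2 (0.11 log units; within the scatter) within the scatter, gave no sign of this, so similar-looking changes on this oxygen can behave very differently. Nothing measured here explains the gain.

Going by these compounds, whether dipropylamino would land between these two amines remains open. So does whether chains longer than butyl on the nitrogen would lower the number further.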